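The source may report more compounds than this note shows. Statements on the series, on what has been measured and on what is new or still open speak of the compounds shown alone.

Working notes on the benzylsulfanyl series. The three measured compounds share one core and differ only in the aryl group on the saturated chain carbon bound to a sulfur. Compound 1 `Cc1cc(S(=O)(=O)/N=C(\N)n2nccc2-c2ccccc2)c(SCc2cccc(Cl)c2)cc1Cl` carries a 3-chlorophenyl there and gives 0.309 h in an ADME assay on microsomes from liver (Homo sapiens) for metabolic stability, read by LC-MS, using NADPH, tested at 5 uM; a higher number here means that the compound lasts longer, a lower number that the compound disappears faster. Compound 2 `Cc1cc(S(=O)(=O)/N=C(\N)n2nccc2-c2ccccc2)c(SCc2ccccc2)cc1Cl` carries a bare phenyl and gives 0.0772 h in this assay; the step between them is a 4.0-fold lower number from compound 1 to compound 2 (0.60 log units; beyond the scatter). Compound 3 `Cc1cc(S(=O)(=O)/N=C(\N)n2nccc2-c2ccccc2)c(SCc2cccc3ccccc23)cc1Cl` carries a naphthalen-1-yl and gives 0.268 h in this assay. On these numbers compound 3 sits close to compound 1, a 1.2-fold lower number from compound 1 to compound 3 (0.06 log units; within the scatter), and further from compound 2, a 3.5-fold higher number from compound 2 to compound 3 (0.54 log units; beyond the scatter).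

Compound 4 `Cc1cc(S(=O)(=O)/N=C(\N)n2nccc2-c2ccccc2)c(SCc2cccc(C(F)(F)F)c2)cc1Cl` is not yet measured. Its change from compound 3: 3-(trifluoromethyl)phenyl in place of naphthalen-1-yl on a saturated chain carbon bound to a sulfur. For the measured compounds named here, two measured steps bear on it. Replacing phenyl by naphthalen-1-yl, a 3.5-fold higher number from compound 2 to compound 3 (0.54 log units; beyond the scatter), was modest and beyond the scatter, whereas replacing 3-chlorophenyl by naphthalen-1-yl, a 1.2-fold lower number from compound 1 to compound 3 (0.06 log units; within the scatter), stayed within the scatter. Compound 4 carries a substituted phenyl, as compound 1 does, rather than the bare phenyl of compound 2. The step into compound 4 is therefore expected to be small, a 1.1-fold higher number from compound 3 to compound 4 (0.05 log units; within the scatter), with no direction beyond the scatter, because a 1.2-fold lower number from compound 1 to compound 3 (0.06 log units; within the scatter) shows a substituted phenyl and naphthalen-1-yl behaving alike. For compound 4 the estimate in this assay is 0.3 h, within 0.15 h to 0.6 h.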

Compound 4, half-life: 0.0863 h
The estimate for compound 4 lay 3.5-fold (0.54 log units) above the measured number; measured number outside the range, below it.
By their numbers in this assay, from the lowest: compounds 2 and 4 (each within the scatter of the next); then compounds 3 and 1 (each within the scatter of the next).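

In this assay, a substituent on the phenyl at this place does not by itself set the half-life: trifluoromethyl in place of chloro on an aromatic carbon gives a 3.6-fold lower number from compound 1 to compound 4 (0.55 log units; beyond the scatter). Trifluoromethyl in place of hydrogen gives a 1.1-fold higher number from compound 2 to compound 4 (0.05 log units; within the scatter), so it does not reproduce the step seen with chloro, a 4.0-fold lower number from compound 1 to compound 2 (0.60 log units; beyond the scatter), and the four compounds fall into two groups, compounds 2 and 4 at one level and compounds 1 and 3 at the other. Matching heavy-atom count does not hold the number either: 3-(trifluoromethyl)phenyl and naphthalen-1-yl both have 10 heavy atoms, yet the change gives a 3.1-fold lower number from compound 3 to compound 4 (0.49 log units; beyond the scatter), and no measurement shown here accounts for the split.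

The compounds shown leave open whether a bromo, a methoxy or a nitrile on this phenyl would fall with chloro or with trifluoromethyl. They also leave open whether the split between chloro and trifluoromethyl persists when an amine or a carboxylic acid is carried on the same aryl group.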